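From trifluoromethoxy to fluoro on a shared core

A few compounds are considered here, and "the series" means these few. Any claim that something is new, unique, unknown or untested is made for them only; others in the source may bear on it.

- compound 1 `CCC1=C(O)c2c(oc(-c3ccc(CC)cc3)cc2=O)C(CC)(CC)C1=O` gives 21.9 uM
- compound 2 `CCC1=C(O)c2c(oc(-c3cccc(C(F)(F)F)c3)cc2=O)C(CC)(CC)C1=O` gives 35.7 uM
- compound 3 `CCC1=C(O)c2c(oc(-c3cccc(OC(F)(F)F)c3)cc2=O)C(CC)(CC)C1=O` gives > 47.4 uM (a limit, not a number)
- compound 4 `CCC1=C(O)c2c(oc(-c3cccc(F)c3)cc2=O)C(CC)(CC)C1=O` has no measurement yet

All of these values come from a functional assay on KB cells (Homo sapiens) for antiproliferative activity, read by sulforhodamine B assay, with a stated time of 3 days; a lower number here means that less compound is needed, a higher number that more compound is needed for the effect. Compound 3 sits at the limit of > 47.4 uM in this assay, at which 1 of the 3 values shown sits, and so has only a limit, not a number.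

Compound 4 keeps the shared core and carries fluoro in place of trifluoromethoxy on an aromatic carbon on the same ring position.

Within the data shown here, one measured step bears on this position. It is an at least 1.3-fold higher number from compound 2 to compound 3 (0.12 log units; that floor lies within the scatter) and it swaps trifluoromethyl for trifluoromethoxy. Among the measured compounds shown here, no measured step involves fluoro, so the support for any forecast is thin.

For the measured compounds named here, compound 2 at 35.7 uM and compound 1 at 21.9 uM give the only real numbers to lean on, and they lie within the scatter of each other. A modest move towards a lower number is therefore expected, and the expected change is an at least 1.5-fold lower number from compound 3 to compound 4 (0.19 log units; that floor lies within the scatter) in this estimate.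

For compound 4 the estimated value is 30 uM with an expected range from 12 uM to 56 uM.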

Compound 4, concentration for half-maximal effect: > 56.2 uM
Compound 4: no number, only a limit; the forecaster's own chance of this, stated with the estimate: 30%; middle value at least 1.8-fold (0.27 log units) from the limit.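

In this assay compound 4 has only a limit, not a number: the limit of > 56.2 uM in this assay, at which 1 of the 4 values shown sits.
Set against trifluoromethyl on the same ring position, fluoro gives an at least 1.5-fold higher number from compound 2 to compound 4 (0.19 log units; that floor lies within the scatter) and so this floor alone does not separate the two groups. Set against the 4-ethylphenyl of compound 1, the 3-fluorophenyl gives an at least 2.5-fold higher number from compound 1 to compound 4 (0.40 log units; beyond the scatter) and this is the first step in the series shown that clears the scatter, so the core with this fluoro group needs clearly more compound than compound 1 does.

The step between compound 3 and compound 4 cannot be read, as both carry only limits, and trifluoromethoxy and fluoro stay unordered. Going by these compounds, it also remains open whether an amine or a carboxylic acid on this ring position would give a real number rather than a limit.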